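Stripping the Dimethylcarbamoyl Down to a Methyl

This account rests on a few compounds, and the source may have more. Where it says the series, first, only, none or still open, it means among the compounds named here.

Compound 2 `CN(C)C(=O)c1cccc(CNc2ccc3[nH]nc(C(=O)O)c3c2)c1O` is the weaker of the two measured compounds in an assay on isolated protein for inhibition of 2-Hydroxyacid oxidase 1 (Homo sapiens), with stated times of 30 min and 15 min; a higher number here means a weaker inhibitor, a lower number a stronger inhibitor. Its value there, > 30000 nM, is a limit of the assay rather than a number (the limit of > 30000 nM in this assay, at which 1 of the 2 values shown sits). Compound 1 `Cc1csc(-c2cccc(CNc3ccc4[nH]nc(C(=O)O)c4c3)c2O)n1` gives 23 nM in this assay, and the change an at least 1300-fold higher number from compound 1 to compound 2 (3.11 log units; beyond the scatter) was large. Compound 3 `Cc1cccc(CNc2ccc3[nH]nc(C(=O)O)c3c2)c1O` differs from compound 2 by methyl in place of dimethylcarbamoyl on an aromatic carbon. That measured step does not cover this change, so no direction can be read from it. Compound 3 is expected to stay weak, with an estimate of 12000 nM (range 1500 nM to 30000 nM), that is an at least 2.5-fold lower number from compound 2 to compound 3 (0.39 log units; beyond the scatter).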

Compound 3, half-maximal inhibitory concentration: 17000 nM
Estimate against measurement, compound 3: 1.4-fold (0.15 log units) below, and the stated range covers the measured number.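

Putting a plain methyl in place of the 4-methyl-1,3-thiazol-2-yl gives a 740-fold higher number from compound 1 to compound 3 (2.87 log units; beyond the scatter), so the large loss in this assay is not peculiar to dimethylcarbamoyl: a single carbon at this position also falls far short of compound 1. Going from dimethylcarbamoyl to methyl gives an at least 1.7-fold lower number from compound 2 to compound 3 (0.24 log units; that floor lies within the scatter), so no real difference between these two groups can be claimed. Compound 2 has a limit of the assay, not a number: the limit of > 30000 nM in this assay, at which 1 of the 3 values shown sits.

Still open, from the compounds shown here alone, is whether a phenyl or an unsubstituted thiazol-2-yl group at this carbon would come close to compound 1 at 23 nM.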